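The source may hold more compounds than are shown below. What is called first, only, known or untested is meant among the compounds shown, and "the series" means these compounds.

Values in a functional assay on HUVEC cells (Homo sapiens) for inhibition; a higher number here means a weaker inhibitor, a lower number a stronger inhibitor:
compound 1 `COc1cc(/C=C/C(=O)c2cccc(NC(=O)c3c(Cl)cccc3Cl)c2)ccc1O`: 0.46 ug/mL
compound 2 `COc1cc(/C=C/C(=O)c2cccc(NC(=O)c3cc(Cl)cc(Cl)c3)c2)ccc1O`: 0.75 ug/mL
compound 3 `COc1cc(/C=C/C(=O)c2cccc(NC(=O)c3ccc(Cl)cc3)c2)ccc1O`: 0.76 ug/mL

Compound 3 sits within the scatter of both other compounds, as a 1.0-fold higher number from compound 2 to compound 3 (0.01 log units; within the scatter) and a 1.7-fold higher number from compound 1 to compound 3 (0.22 log units; within the scatter) show. For the measured compounds named here, the next compound to read is compound 4 `COc1cc(/C=C/C(=O)c2cccc(NC(=O)c3ccco3)c2)ccc1O`, which has no measurement yet. The change is furan-2-yl in place of 4-chlorophenyl on a carbonyl carbon.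

All three measured steps exchange the group at this same place: a 1.6-fold higher number from compound 1 to compound 2 (0.21 log units; within the scatter), a 1.7-fold higher number from compound 1 to compound 3 (0.22 log units; within the scatter) and a 1.0-fold higher number from compound 2 to compound 3 (0.01 log units; within the scatter). Each lies within the scatter, so the series shows no sensitivity to these exchanges so far. Going by the values given here, they cover only 2,6-dichlorophenyl, 3,5-dichlorophenyl and 4-chlorophenyl, and none of the measured compounds carries furan-2-yl, so the evidence is indirect and the range stays wide.

No step beyond the scatter is expected in this assay, and the expected size is a 1.1-fold higher number from compound 3 to compound 4 (0.02 log units; within the scatter). The estimated value for compound 4 is 0.8 ug/mL, with an expected range of 0.35 ug/mL to 1.9 ug/mL.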

Compound 4, half-maximal inhibitory concentration: 0.38 ug/mL
Compound 4: the middle estimate sits 2.1-fold (0.32 log units) above what was measured, and the stated range covers the measured number.
By their numbers in this assay, from the lowest: compounds 4, 1, 2 and 3 (each within the scatter of the next).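

Read in this assay, furan-2-yl on a carbonyl carbon whose other neighbour is the amide-type nitrogen sits with the three chlorinated phenyl groups: the steps (a 2.0-fold lower number from compound 3 to compound 4 (0.30 log units; within the scatter)), (a 2.0-fold lower number from compound 2 to compound 4 (0.30 log units; within the scatter)) and (a 1.2-fold lower number from compound 1 to compound 4 (0.08 log units; within the scatter)) all lie within the scatter. The lack of sensitivity at this place therefore extends beyond chlorinated phenyl groups to a five-membered aromatic ring with one hetero atom, which carries no chlorine and has one hydrogen-bond acceptor. No measurement shown bears on what lies behind this flat reading.

Still open, on these data alone, is whether the flat reading holds for a group with no aromatic ring, such as a basic amine, a carboxylic acid or a longer alkyl chain. Also open, as far as these compounds go, is whether thiophen-2-yl, with sulfur in the ring in place of oxygen, reads like furan-2-yl.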